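Swapping the dinitrophenyl for a hydroxycyclohexyl ether

This account rests on a few compounds, and the source may have more. Where it says the series, first, only, none or still open, it means among the compounds named here.

The series shares a sulfonamide-linked urea and is judged in an ADME assay on HEK-293T cells (Homo sapiens) for cytotoxicity, read by CCK-8 assay, with a stated time of 48 h; on this read-out higher numbers stand for weaker inhibition and lower numbers for stronger inhibition. Compound 1 `COc1ccc(Oc2ccc(C(C)C)cc2-c2ccsc2S(=O)(=O)NCCNC(=O)Nc2cc(Cl)cc(Cl)c2)cc1OC` gives 11900 nM. Compound 2 `O=C(NCCNS(=O)(=O)c1ccc(-c2ccccc2Oc2ccc([N+](=O)[O-])c([N+](=O)[O-])c2)s1)Nc1cc(Cl)cc(Cl)c1` returns only a limit of the assay, > 20000 nM, and not a number. On these data alone, compound 3 `O=C(NCCNS(=O)(=O)c1ccc(-c2ccccc2Oc2ccc([N+](=O)[O-])c([N+](=O)[O-])c2)s1)Nc1cc(C(F)(F)F)cc(C(F)(F)F)c1` likewise returns only a limit, > 50000 nM, so its true value is unknown and it stands at the far weak end of what these three compounds show, with the limit of > 20000 nM in this assay, at which 1 of the 3 values shown sits, and the limit of > 50000 nM in this assay, at which 1 of the 3 values shown sits, marking the two places where the assay stopped counting.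

Compound 4 `O=C(NCCNS(=O)(=O)c1ccc(-c2ccccc2O[C@H]2CC[C@@H](O)CC2)s1)Nc1cc(C(F)(F)F)cc(C(F)(F)F)c1` has not yet been measured. It differs from compound 3 in one place: 4-hydroxycyclohexyl in place of 3,4-dinitrophenyl on an oxygen on an aromatic ring.

Within the data shown here, no single-change step between measured compounds exists here, so the expectation rests on the limit alone. Because compound 3 sits at the limit of > 50000 nM in this assay, at which 1 of the 3 values shown sits, the step in this assay from compound 3 to compound 4 is expected to be small, an at least 1.2-fold lower number from compound 3 to compound 4 (0.09 log units; that floor lies within the scatter), with the chance that compound 4 is again reported only as a limit. Compound 4 is accordingly expected to give about 40000 nM in this assay, within a range from 15000 nM to 100000 nM.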

Compound 4, half-maximal inhibitory concentration: 14100 nM
Beside the measured number, compound 4's estimate is 2.8-fold (0.45 log units) above it, outside the stated range (below it).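

Among these compounds, at the oxygen on an aromatic ring, this change gives the first step that can be read: in this assay, 4-hydroxycyclohexyl in place of 3,4-dinitrophenyl gives an at least 3.5-fold lower number from compound 3 to compound 4 (0.54 log units; beyond the scatter). The group on this oxygen can therefore shift the read-out towards stronger inhibition on its own, so the weak end occupied by compound 3 does not follow from the shared core alone. The true size of the step remains unknown, and only its lower bound can be stated, because compound 3 is reported only as a limit: the limit of > 50000 nM in this assay, at which 1 of the 4 values shown sits.

The compounds shown leave open which part of the change matters: the loss of the two nitro groups, the replacement of the aromatic ring by a non-aromatic one, or the arrival of the hydroxyl group. A plain cyclohexyl or phenyl group on the same oxygen would begin to separate these, a 4-aminocyclohexyl group would test a different substituent on the ring, and the other stereoisomer of the 4-hydroxycyclohexyl group would show whether its spatial arrangement counts.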